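Swapping the Furan Amide for a Methyl-Isoxazole

A few compounds are considered here, and "the series" means these few. Any claim that something is new, unique, unknown or untested is made for them only; others in the source may bear on it.

Two compounds share a core in which a methylpyrrolidinyl-pyrrolidine is attached to an aryl ring bearing an amide. Compound 1 `Cc1cc(N2CC[C@H](N3CCC[C@@H]3C)C2)ccc1NC(=O)c1ccoc1` carries a furan-3-yl on the carbonyl carbon, and in an assay on CHO cells for displacement of a labelled ligand from histamine receptor H3 (Macaca mulatta), read by scintillation counting, with a stated time of 1 h (on this read-out higher numbers stand for weaker inhibition and lower numbers for stronger inhibition), compound 1 gives 1.8 nM. Compound 2 `Cc1nc(N2CC[C@H](N3CCC[C@@H]3C)C2)ccc1NC(=O)c1cccc2ccccc12` carries a naphthalene carbonyl on a pyridine-type core, and in this assay compound 2 gives 4.2 nM. Compound 1 thus stands with the lowest number of the two, and its gap to compound 2 lies beyond the scatter.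

Compound 3 `Cc1cc(C(=O)Nc2ccc(N3CC[C@H](N4CCC[C@@H]4C)C3)cc2C)on1` is not yet measured. It differs from compound 1 by 3-methyl-1,2-oxazol-5-yl in place of furan-3-yl on a carbonyl carbon. For the measured compounds named here, no step of this kind is available among the measured compounds, so the expectation rests on the two values alone: a small change in either direction, or none beyond the scatter, is expected, with the step from a 1.7-fold higher number from compound 1 to compound 3 (0.22 log units; within the scatter) estimated to lean slightly toward a higher number. Compound 3 is therefore expected to give about 3 nM in this assay, within a range from 1 nM to 10 nM.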

Compound 3, inhibition constant: 1.1 nM
For compound 3 the middle estimate is 2.7-fold (0.44 log units) above the measured one; measured number inside the range.
By their numbers in this assay, from the lowest: compounds 3 and 1 (each within the scatter of the next); then compound 2.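

On the carbonyl carbon, 3-methyl-1,2-oxazol-5-yl in place of furan-3-yl gives a 1.6-fold lower number from compound 1 to compound 3 (0.21 log units; within the scatter) in this assay, so this read-out does not separate the two groups. For the compounds shown here, this is the first comparison in the set that differs in one place only, and it shows that at this position a five-membered aromatic ring with 2 hetero atoms and a methyl group can stand in for one with 1 hetero atom without a change beyond the scatter. Nothing given here bears on what lies behind this result.

Still open, on these data alone, is whether the methyl group matters, which the plain 1,2-oxazol-5-yl group would test. Also open, as far as these compounds go, is how this assay responds when the carbonyl carbon carries a cyclohexyl ring, an amine or a carboxylic acid instead of a five-membered aromatic ring.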